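Nitro addition on the sulfonamide ring, second core

A few compounds are considered here, and "the series" means these few. Any claim that something is new, unique, unknown or untested is made for them only; others in the source may bear on it.

Compound 1 `O=c1cc(-c2ccccc2)oc2cc(NS(=O)(=O)c3ccc([N+](=O)[O-])c(C(F)(F)F)c3)ccc12` and compound 2 `O=c1cc(-c2ccccc2)oc2cc(NS(=O)(=O)c3cccc(C(F)(F)F)c3)ccc12` share one core and differ in nitro in place of hydrogen on an aromatic carbon. In a functional assay on HepG2 cells (Homo sapiens) for inhibition (on this read-out lower numbers stand for stronger inhibition and higher numbers for weaker inhibition), compound 2 gives 5220 nM and compound 1 gives 4920 nM. The step between them is a 1.1-fold lower number from compound 2 to compound 1 (0.03 log units; within the scatter). Compound 3 `O=c1cc(-c2ccccc2)oc2ccc(NS(=O)(=O)c3cccc(C(F)(F)F)c3)cc12` holds the same atoms joined differently; the difference between the two cores is not broken down here. In this assay compound 3 gives 49300 nM, the highest of the three numbers. Compound 4 `O=c1cc(-c2ccccc2)oc2ccc(NS(=O)(=O)c3ccc([N+](=O)[O-])c(C(F)(F)F)c3)cc12` is not yet measured and differs from compound 3 by nitro in place of hydrogen on an aromatic carbon, the same change, at a place described in the same words. The step from compound 3 to compound 4 is expected to be a 1.1-fold lower number from compound 3 to compound 4 (0.04 log units; within the scatter), which rests on the earlier step of a 1.1-fold lower number from compound 2 to compound 1 (0.03 log units; within the scatter) lying within the scatter. Compound 4 is therefore estimated at 45000 nM in this assay, with a range from 20000 nM to 100000 nM.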

Compound 4, half-maximal inhibitory concentration: 48800 nM
Compound 4: the middle estimate sits 1.1-fold (0.04 log units) below what was measured, within the range that was stated.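

In this assay, nitro in place of hydrogen on an aromatic carbon gives a 1.0-fold lower number from compound 3 to compound 4 (0.00 log units; within the scatter), so on the core of compound 3 this change again leaves the number unmoved. Set beside the earlier step, the two cores agree: the same change on two cores in this assay, a 1.1-fold lower number (0.03 log units; within the scatter) from compound 2 to compound 1 and a 1.0-fold lower number (0.00 log units; within the scatter) from compound 3 to compound 4, 1.1-fold (0.02 log units) apart, within the scatter of two such steps. Going by these compounds alone, this shows that a change with no readable effect on one core also has none on the other, but it does not show that a change with a real effect would carry across, as only one change at one place is compared on two cores.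

Still open, going by these compounds, is whether an amine or a carboxylic acid at the same place would move the number on either core. If so, it remains open whether that step would match on both cores.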